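The source may hold more compounds than are shown below. What is called first, only, known or untested is meant among the compounds shown, and "the series" means these compounds.

Measured so far:
compound 1, `CCCCCOc1c(-c2cc(OC)c(OC)c(OC)c2)oc2ccccc2c1=O`: 15400 nM
compound 2, `CCN(CC)CCCCOc1c(-c2cc(OC)c(OC)c(OC)c2)oc2ccccc2c1=O`: 13500 nM
compound 3, `CCCN(CCC)CCCOc1c(-c2cc(OC)c(OC)c(OC)c2)oc2ccccc2c1=O`: 17900 nM

All three were tested in a functional assay on LNCaP cells (Homo sapiens) for antiproliferative activity, read by WST assay, with a stated time of 3 days; on this read-out lower numbers stand for stronger inhibition and higher numbers for weaker inhibition. On these three numbers compound 1 stands second highest. Its nearest neighbour is compound 2, with a 1.1-fold lower number from compound 1 to compound 2 (0.06 log units; within the scatter), and its furthest is compound 3, with a 1.2-fold higher number from compound 1 to compound 3 (0.07 log units; within the scatter); between the two amine-bearing compounds the step is a 1.3-fold higher number from compound 2 to compound 3 (0.12 log units; within the scatter). None of these steps stands out from the scatter, so the three compounds read as a group of roughly equal numbers.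

The step from compound 1 to compound 4, `CCCN(CCC)CCCCOc1c(-c2cc(OC)c(OC)c(OC)c2)oc2ccccc2c1=O`, is this change:

dipropylamino in place of methyl on a saturated chain carbon, four bonds along the chain from an oxygen on an aromatic ring

Going by the values given here, two measured steps bear on it. The step from compound 1 to compound 2 places a diethylamino at the same place; the step from compound 1 to compound 3 places a dipropylamino one bond closer to the oxygen. Both remained within the scatter, and so did the step between compound 2 and compound 3. There is no sign here that putting a dialkylamino group at the end of this chain changes the number in this assay beyond the scatter, in either direction. The step expected from compound 1 to compound 4 is therefore a 1.0-fold lower number from compound 1 to compound 4 (0.01 log units; within the scatter). Compound 4 is estimated to give 15000 nM, with a likely range from 7500 nM to 30000 nM.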

Compound 4, half-maximal inhibitory concentration: 16800 nM
For compound 4 the middle estimate is 1.1-fold (0.05 log units) below the measured one, within the range that was stated.
By their numbers in this assay, from the lowest: compounds 2, 1, 4 and 3 (each within the scatter of the next).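

With dipropylamino four bonds along the chain from an oxygen on an aromatic ring, the direct replacement of methyl in this assay gives a 1.1-fold higher number from compound 1 to compound 4 (0.04 log units; within the scatter) and so stays within the scatter, which until now had been seen only for two related changes. Compound 4 also allows each feature to be read separately: exchanging diethylamino for dipropylamino at this same place gives a 1.2-fold higher number from compound 2 to compound 4 (0.09 log units; within the scatter), and placing (dipropylamino)methyl in place of dipropylamino, three bonds along the chain from that oxygen, gives a 1.1-fold lower number from compound 3 to compound 4 (0.03 log units; within the scatter). Among these four compounds, neither of these two exchanges separates the numbers from the scatter, and no measurement available here gives any further account of this result.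

The compounds shown leave open whether an amine closed into a ring, such as piperidine or morpholine, or a much longer chain ending in an amine would give a number beyond the scatter. They also leave open what a carboxylic acid at the end of the chain, or a change to the shared core itself, would do to the number.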